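Methoxyphenoxy acetamide piperazines: cytotoxicity working notes

The source may report more compounds than this note shows. Statements on the series, on what has been measured and on what is new or still open speak of the compounds shown alone.

The series is read in a functional assay on PC-12 cells (Rattus norvegicus) for cytotoxicity, read by MTT assay, with a stated time of 24 h, tested at 0.1 uM; on this read-out lower numbers stand for a weaker effect and higher numbers for a stronger effect at the one concentration tested. Compound 1 `COc1ccc(OCC(=O)N2CCN(C(c3ccc(F)cc3)c3ccc(F)cc3)CC2)cc1` gives 3.1% in this assay. Compound 2 `COc1ccc(OCC(=O)N2CCN(C(c3ccc(C)cc3)c3ccc(C)cc3)CC2)cc1` gives 21.7% in this assay. Within the data shown here, of the two numbers known, compound 1 stands lowest; its nearest neighbour is compound 2, which lies higher by a gap beyond the scatter. Among the measured compounds shown here, no pair of measured compounds differs in a single place, so no step within the measured set can be stated; the two values are simply what they are.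

Compound 3 `COc1ccccc1OCC(=O)N1CCN(C(c2ccc(F)cc2)c2ccc(F)cc2)CC1` has not been measured in this assay. It has the same atoms as compound 1, joined differently: 2-methoxyphenyl in place of 4-methoxyphenyl on an oxygen on a saturated carbon. The change thus sits entirely within the methoxyphenyl on the oxygen on a saturated carbon, away from the part where compound 1 and compound 2 differ, and nothing in the measured set shows what this rearrangement does. The step is expected to be small, a number 2.9 percentage points higher from compound 1 to compound 3 (within the scatter), with no clear direction beyond the scatter. Compound 3 is estimated at 6%, with a range from 0% to 20%.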

Compound 3, a percentage reported as activity, at one concentration (the size of the read-out at that concentration, not a potency): 32%
The estimate for compound 3 lay 26 percentage points below the measured number; the measured number lies above the stated range.
By their numbers in this assay, from the lowest: compound 1; then compound 2; then compound 3.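

With the atoms unchanged, 2-methoxyphenyl in place of 4-methoxyphenyl on an oxygen on a saturated carbon gives a number 28.9 percentage points higher from compound 1 to compound 3 (beyond the scatter) in this assay, so the read-out depends on how the methoxyphenyl is joined and not only on its atoms. The earlier compounds shown here offered no view of this place, and it now counts as one where a rearrangement alone moves the number beyond the scatter, although this rests on a single pair with the core of compound 1. No available evidence bears on the reason for this step.

The compounds shown leave open whether the same rearrangement gives a step of similar size on the core of compound 2, and so whether the effect holds beyond the fluorinated compounds. They also leave open what an ethoxy group, a hydroxyl or a carboxylic acid would do in place of the methoxy group of 2-methoxyphenyl, and a read-out at one concentration gives no potency for any of these compounds.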